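The source may report more compounds than this note shows. Statements on the series, on what has been measured and on what is new or still open speak of the compounds shown alone.

Working notes on the series built on the shared core of compound 1 (`Cc1nc(-c2ccccc2F)c(C(=O)N2CCN(c3cc(Cl)ccc3C)CC2)o1`). In a functional assay on HL-60 cells (Homo sapiens) for inhibition, read by MTT assay, with a stated time of 72 h (a higher number here means a weaker inhibitor, a lower number a stronger inhibitor), compound 1 gives 229 nM, compound 2 (`Cc1nc(-c2cccc(F)c2)c(C(=O)N2CCN(c3cccc(Cl)c3)CC2)o1`) gives 33.7 nM, and compound 3 (`Cc1nc(-c2ccccc2F)c(C(=O)N2CCN(c3cc(Cl)cc(Cl)c3)CC2)o1`) gives 60.2 nM. Compound 3 therefore sits within the scatter of compound 2 and well apart from compound 1.

The next compound is compound 4 (`Cc1ccc(C)c(N2CCN(C(=O)c3oc(C)nc3-c3ccccc3F)CC2)c1`), with 2,5-dimethylphenyl in place of 3,5-dichlorophenyl on an amine nitrogen in a ring.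

For the measured compounds named here, one measured step bears directly on this change: a 3.8-fold lower number from compound 1 to compound 3 (0.58 log units; beyond the scatter), made at the same amine nitrogen. Compound 2 differs from compound 3 in more than one place, so it gives no clean comparison. Like compound 4, compound 1 lacks the 3,5-dichlorophenyl group and has a methyl group on that aromatic ring, which makes it the nearest measured neighbour. Going by the values given here, no measured pair isolates the remaining difference between compound 1 and compound 4. Leaving the 3,5-dichlorophenyl group is thus expected to reverse most of the measured step, taking the number back towards the 229 nM of compound 1.

The expected change is a 3.7-fold higher number from compound 3 to compound 4 (0.56 log units; beyond the scatter), a modest rise beyond the scatter. For compound 4 the estimated value is 220 nM, with an expected range of 80 nM to 600 nM.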

Compound 4, half-maximal inhibitory concentration: 319 nM
The estimate for compound 4 lay 1.5-fold (0.16 log units) below the measured number, within the range that was stated.
By their numbers in this assay, from the lowest: compounds 2 and 3 (each within the scatter of the next); then compounds 1 and 4 (each within the scatter of the next).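

In this assay, the step of a 5.3-fold higher number from compound 3 to compound 4 (0.72 log units; beyond the scatter) shows that the 3,5-dichlorophenyl group on the amine nitrogen cannot be replaced by 2,5-dimethylphenyl without a loss beyond the scatter, which is a second reading at this position, now with no chlorine left on that ring. The step of a 1.4-fold higher number from compound 1 to compound 4 (0.14 log units; within the scatter), methyl in place of chloro on an aromatic carbon, stays within the scatter, so this one swap on a ring that already carries a methyl group shows no measurable change, and compound 1 and compound 4 stand together apart from compound 3. The numbers come with no accompanying measurement that could account for this separation.

The compounds shown leave open whether the level of compound 3 depends on its two chloro groups or on where they sit, as compound 2 differs from compound 3 in more than one place and gives no clean reading. A 3,5-dimethylphenyl group on the same amine nitrogen would separate the placement of the substituents from their identity, and 3,5-dimethoxyphenyl would extend that comparison to a different substituent.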